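Dropping the amino group from a chloropurine cytotoxicity probe

The source may report more compounds than this note shows. Statements on the series, on what has been measured and on what is new or still open speak of the compounds shown alone.

The study concerns two measured compounds and one still untested, all assessed in a functional assay on LOX IMVI cells (Homo sapiens) for cytotoxicity, read by sulforhodamine B assay, with a stated time of 48 h; a higher number here means that more compound is tolerated, a lower number that less compound is tolerated. Compound 1 `Nc1nc(Cl)c2ncn(Cc3ccccc3CCl)c2n1` did not give a number in this assay: its value, > 100000 nM, is a limit of the assay, so the compound tolerated the highest concentration tested and its true position is known only as a bound (the limit of > 100000 nM in this assay, at which 1 of the 2 values shown sits). Compound 2 `ClCc1ccccc1Cn1cnc2ncnc(Cl)c21` did give a number, showing 7070 nM in this assay.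

The untested compound 3 `ClCc1ccccc1Cn1cnc2c(Cl)ncnc21` differs from compound 1 in a single place: hydrogen in place of amino on an aromatic carbon. Among the compounds with values here, no measured step bridges compound 1 and compound 3, so the size of the change must be guessed. Given that compound 1 sits at the limit of this assay, the author expects the move from compound 1 to compound 3 to bring a lower number, likely beyond the scatter, estimated as an at least 3.3-fold lower number from compound 1 to compound 3 (0.52 log units; beyond the scatter), though the limit makes the true size uncertain. For compound 3 the estimated value in this assay is therefore 30000 nM, with a range from 5000 nM to 150000 nM.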

Compound 3, concentration lethal to 50% of the cells: > 100000 nM
Compound 3: a limit, no number; the forecaster's own chance of this, stated with the estimate: 35%; middle value at least 3.3-fold (0.52 log units) from the limit.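

In this assay compound 3 gives > 100000 nM, which is a limit and not a number. Compound 1 also stands at a limit, so no step can be read between compound 1 and compound 3: the limit of > 100000 nM in this assay, at which 2 of the 3 values shown sit. The compounds shown leave open whether hydrogen in place of amino on an aromatic carbon changes the value at all.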